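Furan-to-chlorophenyl swap at the chain terminus, gastric cell line

The source may hold more compounds than are shown below. What is called first, only, known or untested is meant among the compounds shown, and "the series" means these compounds.

Three chalcone-linked flavone ethers have been measured in a functional assay on SGC-7901 cells (Homo sapiens) for antiproliferative activity, read by MTT assay, with a stated time of 48 h; on this read-out higher numbers stand for weaker inhibition and lower numbers for stronger inhibition. Compound 1 `COc1cc(OC)c2c(=O)c(OCCCOc3ccccc3/C=C/C(=O)/C=C/c3cccc([N+](=O)[O-])c3)c(-c3cc(OC)c(OC)c(OC)c3)oc2c1` gives 5400 nM, compound 2 `COc1cc(OC)c2c(=O)c(OCCCOc3ccccc3/C=C/C(=O)/C=C/c3scnc3C)c(-c3cc(OC)c(OC)c(OC)c3)oc2c1` gives 4780 nM, and compound 3 `COc1cc(OC)c2c(=O)c(OCCCCOc3ccccc3/C=C/C(=O)/C=C/c3ccco3)c(-c3cc(OC)c(OC)c(OC)c3)oc2c1` gives 8980 nM. Compound 3 carries the highest of the three numbers, but its gaps to compound 1 and to compound 2 are both within the usual scatter, so no ordering among them is secure.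

Compound 4 `COc1cc(OC)c2c(=O)c(OCCCCOc3ccccc3/C=C/C(=O)/C=C/c3ccc(Cl)cc3)c(-c3cc(OC)c(OC)c(OC)c3)oc2c1` differs from compound 3 by 4-chlorophenyl in place of furan-2-yl on a double-bonded chain carbon bound to a double-bonded chain carbon. For the measured compounds named here, the one measured step at this position is a 1.1-fold lower number from compound 1 to compound 2 (0.05 log units; within the scatter), where a six-membered carbon ring gave way to a five-membered heteroaromatic ring without a shift beyond the scatter. The change to compound 4 is the reverse kind of swap, and nothing in the series shows the terminal ring moving this assay. Compound 4 is therefore expected to sit near compound 3, with an estimated step of a 1.3-fold lower number from compound 3 to compound 4 (0.11 log units; within the scatter). The estimate for compound 4 in this assay is 7000 nM, with a range from 3500 nM to 14000 nM.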

Compound 4, half-maximal inhibitory concentration: 9150 nM
For compound 4 the middle estimate is 1.3-fold (0.12 log units) below the measured one, within the range that was stated.
By their numbers in this assay, from the lowest: compounds 2, 1, 3 and 4 (each within the scatter of the next).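

In this assay, 4-chlorophenyl in place of furan-2-yl gives a 1.0-fold higher number from compound 3 to compound 4 (0.01 log units; within the scatter), so this position now has a second step within the scatter, this one on the compounds with the longer chain. This swap differs from the earlier one in carrying chlorine in and taking the hydrogen-bond acceptor of furan-2-yl out, and the read-out still does not separate the two terminal groups. No supporting data bear on why the number holds across this swap.

Still open, on these data alone, is whether an amine or a carboxylic acid on the terminal ring would give a step beyond the scatter. The linking chain is also unresolved, as in the compounds shown it differs only together with the terminal ring.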